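The source may report more compounds than this note shows. Statements on the series, on what has been measured and on what is new or still open speak of the compounds shown alone.

Measured so far:
compound 1, `NS(=O)(=O)Oc1ccc2c(c1)CN(C(=O)c1cccc(N3CCN(c4ncccn4)CC3)c1)CC2`, in an assay on HEK293 cells for inhibition of Steryl-sulfatase (Homo sapiens), tested at 1 uM; a higher number here means a stronger effect of the compound at the concentration tested, a lower number a weaker effect: 24.4%
compound 2, `CCN(Cc1ccccn1)c1ccc(C(=O)N2CCc3ccc(OS(N)(=O)=O)cc3C2)cc1`: 87.7%
compound 3, `CCN(Cc1ccncc1)c1cccc(C(=O)N2CCc3ccc(OS(N)(=O)=O)cc3C2)c1`: 52.8%

All three compounds share the same core, an amide-linked sulfamate-bearing bicycle, and differ only in the group attached to the benzamide part. Among the three numbers, compound 3 stands second highest: compound 1 sits lower by a gap beyond the usual scatter of this assay, and compound 2 sits higher, again by a gap beyond the scatter. Compound 3 thus lies in the middle of a wide spread.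

Compound 4, `CCCN(CCC)c1cccc(C(=O)N2CCc3ccc(OS(N)(=O)=O)cc3C2)c1`, has not yet been measured. It differs from compound 3 in one place: dipropylamino in place of ethyl((pyridin-4-yl)methyl)amino on an aromatic carbon. For the measured compounds named here, no two measured compounds differ from each other in a single place, so there is no measured step of this kind to lean on. The group that leaves carries a ring, the group that enters carries none, and the three measured values give no direct guide to what such a swap does.

For compound 4 the expectation is a step no larger than the scatter, a number 4.8 percentage points lower from compound 3 to compound 4 (within the scatter). The estimated value for compound 4 in this assay is 48%, within a range from 22% to 78%.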

Compound 4, a percentage reported as inhibition, at one concentration (the size of the read-out at that concentration, not a potency): 54.8%
Beside the measured number, compound 4's estimate is 6.8 percentage points below it, within the range that was stated.
By their numbers in this assay, from the lowest: compound 1; then compounds 3 and 4 (each within the scatter of the next); then compound 2.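

In this assay, for the compounds shown here, putting dipropylamino in place of ethyl((pyridin-4-yl)methyl)amino on this aromatic carbon gives a number 2 percentage points higher from compound 3 to compound 4 (within the scatter) and provides the first comparison in which only one place changes. The two compounds cannot be told apart in this read-out, even though the entering group has no ring, fewer heavy atoms and fewer hydrogen-bond acceptors than the group that leaves, so at this position the six-membered aromatic ring of the leaving group is not required for a reading of this size. No measurement available here explains why two such different groups read alike.

This single step leaves open whether other groups on the same carbon, such as diethylamino, a morpholine ring or a chain ending in a carboxylic acid, would also read alike or would move the number beyond the scatter. It also leaves open whether the two compounds would still match in a full potency measurement, as the read-out here comes from one concentration and gives the size of the effect there, not a potency.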